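The source may hold more compounds than are shown below. What is called first, only, known or untested is meant among the compounds shown, and "the series" means these compounds.

Measured so far in an ADME assay on HFF cells (Homo sapiens) for cytotoxicity, with a stated time of 8 days; a lower number here means that less compound is tolerated, a higher number that more compound is tolerated:
Compound 1 `CCCCSc1nc(N)nc2c1ncn2/C=C1/CC1(CO)CO` gives > 300000 nM, which is a limit rather than a number.
Compound 2 `CCCCCOc1nc(N)nc2c1ncn2/C=C1/CC1(CO)CO` gives 259000 nM.
Compound 3 `CCCCNc1nc(N)nc2c1ncn2/C=C1/CC1(CO)CO` gives > 300000 nM, again a limit rather than a number.

Compound 3 thus stands only at a limit, a position it shares with one further value (the limit of > 300000 nM in this assay, at which 2 of the 3 values shown sit). The step of an at least 1.1-fold higher number from compound 2 to compound 3 (0.06 log units; that floor lies within the scatter) is readable only as a floor, and the step that the two limits leave unreadable from compound 1 to compound 3 is not readable at all. Compound 4 `CC(C)Nc1nc(N)nc2c1ncn2/C=C1/CC1(CO)CO` differs from compound 3 by isopropyl in place of butyl on a nitrogen on an aromatic ring. Going by the values given here, no measured step alters the group on the nitrogen; all measured steps exchange the linking atom, and none of them leaves the scatter. The step of a number no higher from compound 3 to compound 4 (the limit leaves the size open) is therefore expected to stay within the scatter. Compound 4 is estimated at 300000 nM, between 150000 nM and 600000 nM, with a fair chance that only a limit is recorded.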

Compound 4, half-maximal cytotoxic concentration: > 300000 nM
Compound 4: a limit, no number; the forecaster's own chance of this, stated with the estimate: 60%; the middle value sits exactly at the limit.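

Isopropyl in place of butyl is the first change to the group on this nitrogen, and in this assay compound 4 gives > 300000 nM, a limit rather than a number. Going by these compounds alone, the only readable step is an at least 1.1-fold higher number from compound 2 to compound 4 (0.06 log units; that floor lies within the scatter); the steps to compound 4 from compound 3 and from compound 1 cannot be read. Butylamino and isopropylamino thus both sit at the limit: the limit of > 300000 nM in this assay, at which 3 of the 4 values shown sit.

No order among butylsulfanyl, butylamino and isopropylamino can be given from limits. As far as these compounds go, whether a carboxylic acid or a longer chain on this nitrogen would give a readable number stays open.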